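The source may hold more compounds than are shown below. What is called first, only, known or untested is meant among the compounds shown, and "the series" means these compounds.

Compound 1 `C[C@@H](C(=O)N[C@H](C#N)CC(N)=O)N(Cc1ccc(-c2cc(F)cc(F)c2)cc1)S(C)(=O)=O` gives 1360 nM in an assay on isolated protein for inhibition of legumain (Homo sapiens), with stated times of 2 min and 60 min; on this read-out higher numbers stand for weaker inhibition and lower numbers for stronger inhibition.
Compound 2 `C[C@@H](C(=O)N[C@H](C#N)CC(N)=O)N(Cc1ccc(-c2cccc(F)c2F)cc1)S(=O)(=O)c1ccccc1` gives > 10000 nM in this assay, which is a limit of the assay and not a number.
Compound 3 `CS(=O)(=O)N(CC(=O)N[C@H](C#N)CC(N)=O)Cc1ccc(-c2cccc(F)c2)cc1` gives > 10000 nM in this assay, again a limit rather than a number.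

All three compounds share the same core, with a nitrile-bearing amide chain on one side and a sulfonyl group on the other, and differ in the aromatic rings attached to them. Of the three values shown, only compound 1 is an actual number; compound 2 sits at the limit of > 10000 nM in this assay, at which 2 of the 3 values shown sit, as does one further compound. Compound 2 therefore stands at the weak end of what this assay can report, with no number of its own.

Compound 4 `C[C@@H](C(=O)N[C@H](C#N)CC(N)=O)N(Cc1ccc(-c2cccc(F)c2)cc1)S(=O)(=O)c1ccccc1` is the next compound, and it differs from compound 2 in one place: hydrogen in place of fluoro on an aromatic carbon. Among the measured compounds shown here, no pair of measured compounds differs in one place, so the size of this kind of change has not been seen here. Since compound 2 shows only a limit, the step from compound 2 to compound 4 is expected to be about an at least 1.1-fold lower number from compound 2 to compound 4 (0.04 log units; that floor lies within the scatter), that is, no clear change beyond the usual scatter, with a fair chance that compound 4 also yields only a limit. Compound 4 is expected to give roughly 9000 nM, somewhere between 3000 nM and 30000 nM.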

Compound 4, half-maximal inhibitory concentration: > 10000 nM
Compound 4 was reported as a limit; the forecaster's own chance of this, stated with the estimate: 55%; at least 1.1-fold (0.04 log units) between middle value and limit.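

Compound 2 and compound 4 are both reported only as limits of the assay, so the step between them, hydrogen in place of fluoro, cannot be read: the limit of > 10000 nM in this assay, at which 3 of the 4 values shown sit. The compounds shown leave open how much the change from 2,3-difluorophenyl to 3-fluorophenyl alters the result in this assay.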